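Adding a methyl to the hydroxy of compound 3

The compounds below may be only part of what the source reports. "The series", "measured", "known", "first", "only" and "open" are said of these compounds alone.

- compound 1 `CC1(/C=C/c2ccc(C(F)(F)F)cc2)C=CC(=O)O1`: 9400 nM
- compound 2 `COc1ccc(/C=C/C2(C)C=CC(=O)O2)cc1OC`: 111000 nM
- compound 3 `CC1(/C=C/c2ccc(O)cc2)C=CC(=O)O1`: 111000 nM

In a functional assay on NCI/ADR-RES cells (Homo sapiens) for inhibition, read by sulforhodamine B assay, with a stated time of 48 h (a higher number here means a weaker inhibitor of growth, a lower number a stronger inhibitor of growth), compound 3 gives 111000 nM, the same number as compound 2 at 111000 nM. Compound 1 stands well apart from both at 9400 nM.

The next compound is compound 4 `COc1ccc(/C=C/C2(C)C=CC(=O)O2)cc1`, which differs from compound 3 by one small edit: methyl in place of hydrogen on an oxygen on an aromatic ring. Hydroxy becomes methoxy.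

Within the data shown here, only one measured step touches this part of the molecule: a 12-fold higher number from compound 1 to compound 3 (1.07 log units; beyond the scatter). That swap, hydroxy in place of trifluoromethyl on an aromatic carbon, shows that a change on the aromatic ring can move this number a long way. Among the measured compounds shown here, it is a different swap, however, and no measured step replaces hydroxy with methoxy directly.

The closest guide is compound 2 at 111000 nM, which also carries methoxy on its aromatic ring and shares its number with compound 3. A large step therefore seems unlikely. The expected change is a 1.4-fold lower number from compound 3 to compound 4 (0.14 log units; within the scatter), so no real shift is anticipated. For compound 4 the estimated value is 80000 nM, with an expected range of 25000 nM to 130000 nM.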

Compound 4, concentration for total growth inhibition: > 1000000 nM
Compound 4: a limit, no number; the forecaster's own chance of this, stated with the estimate: 20%; at least 12-fold (1.09 log units) between middle value and limit.
By their numbers in this assay, from the lowest: compound 1; then compounds 2 and 3 (each within the scatter of the next). At a limit, above all of these: compound 4.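

In this assay compound 4 gives no number, only a limit of the assay: the limit of > 1000000 nM in this assay, at which 1 of the 4 values shown sits.

The earlier compounds shown here suggested that methoxy on the ring might change little, but a single added methyl on this oxygen gives an at least 9.0-fold higher number from compound 3 to compound 4 (0.95 log units; beyond the scatter), so the free hydroxy cannot be capped here without a clear loss in this read-out. The other two comparisons show that this position is not the whole story: hydrogen in place of methoxy on an aromatic carbon gives an at least 9.0-fold higher number from compound 2 to compound 4 (0.95 log units; beyond the scatter), and putting methoxy where trifluoromethyl stood gives an at least 100-fold higher number from compound 1 to compound 4 (2.02 log units; beyond the scatter), so a lone methoxy does not behave like the ring substitution of compound 2 or compound 1.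

Going by these compounds, it stays open whether any group on this oxygen has the same result, and an ethyl or a longer chain there, or an amine on the aromatic carbon instead of the hydroxy, would help to settle that. On these data alone, the full size of all three steps also stays open, as compound 4 has a limit and not a number.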